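Swapping Chloro for Methoxy on a Weak Cytotoxic Series

The compounds below may be only part of what the source reports. "The series", "measured", "known", "first", "only" and "open" are said of these compounds alone.

Measured so far:
compound 1, `COc1cc(N)c(C(=N)Nc2cccc(Cl)c2)cc1OC`, 460000 nM
compound 2, `COc1cccc(NC(=N)c2cc(OC)c(OC)cc2N)c1`, 340000 nM
compound 3, `COc1cc2c(cc1OC)C(Nc1cccc(Cl)c1)=NC(C)(C)N2`, 200000 nM

All three compounds were tested in a functional assay on A-431 cells (Homo sapiens) for cytotoxicity (a lower number here means a stronger inhibitor, a higher number a weaker inhibitor), and all three give very high numbers, so none of them is a strong inhibitor. Compound 1 and compound 2 share one core and differ by methoxy in place of chloro on an aromatic carbon. That change gave a 1.4-fold lower number from compound 1 to compound 2 (0.13 log units; within the scatter), so the two values cannot be told apart with confidence.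

Compound 3 carries a different, larger core; how the core of compound 1 and the core of compound 3 differ is not broken down here. Compound 3 gives a number in this assay that sits close to compound 2 and somewhat further from compound 1, the latter gap lying beyond the usual scatter.

Compound 4, `COc1cccc(NC2=NC(C)(C)Nc3cc(OC)c(OC)cc32)c1`, is not yet measured. It differs from compound 3 by methoxy in place of chloro on an aromatic carbon. Going by the values given here, this is the same change already seen between compound 1 and compound 2, at the same kind of place on the ring, so the earlier pair is the only guide available.

The step of a 1.3-fold lower number from compound 3 to compound 4 (0.12 log units; within the scatter) is expected to be small because the matching earlier change gave a 1.4-fold lower number from compound 1 to compound 2 (0.13 log units; within the scatter). On that basis compound 4 is estimated at 150000 nM in this assay, with a likely range from 70000 nM to 350000 nM.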

Compound 4, half-maximal inhibitory concentration: 320000 nM
Beside the measured number, compound 4's estimate is 2.1-fold (0.33 log units) below it, and the stated range covers the measured number.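

In this assay the swap of 3-chlorophenyl to 3-methoxyphenyl on the core of compound 3 gives a 1.6-fold higher number from compound 3 to compound 4 (0.20 log units; within the scatter) and so, like the same swap on the core of compound 1, leaves a difference too small to read as real. This shows that the change made no clear difference on either core, but it does not show a fixed size or direction for the change, and a single pair on each core is thin support for any rule, especially with all four compounds giving very high numbers. The two steps point opposite ways on paper, yet the gap between them is no larger than repeated measurements could produce, so the two cores cannot be said to respond differently to this change: the same change on two cores in this assay, a 1.4-fold lower number (0.13 log units; within the scatter) from compound 1 to compound 2 and a 1.6-fold higher number (0.20 log units; within the scatter) from compound 3 to compound 4, 2.2-fold (0.34 log units) apart, within the scatter of two such steps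

Going by these compounds, only chloro and methoxy appear at this place on the ring, so it remains open whether a different group there, such as an amine, a carboxylic acid or a longer chain, would shift the number beyond the scatter on either core. On these data alone, it also remains open whether the same swap would stay this small on a compound that is a much stronger inhibitor than these four.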